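The compounds below may be only part of what the source reports. "The series", "measured", "known", "first", "only" and "open" are said of these compounds alone.

In a functional assay on A549 cells (Homo sapiens) for cytotoxicity, read by MTT assay, with a stated time of 72 h (a higher number here means a weaker inhibitor, a lower number a stronger inhibitor), compound 1 (`CCc1ccc(-c2cc(C(=O)Nc3ccc(Oc4ccnc(C(=O)NC)c4)cc3)ncn2)cc1`) gives 13300 nM and stands in the middle of three measured numbers, with compound 2 (`CCc1ccc(-c2cc(C(=O)Nc3ccc(Oc4ccnc(C(=O)NC)c4)c(F)c3)ncn2)cc1`) lower at 3390 nM and compound 3 (`CNC(=O)c1cc(Oc2ccc(NC(=O)c3nccc(-c4ccc(C)cc4)n3)cc2)ccn1`) higher at 28400 nM. Compound 4 (`CNC(=O)c1cc(Oc2ccc(NC(=O)c3cc(-c4ccc(OC)cc4)ncn3)cc2)ccn1`) keeps the core of compound 1 but carries methoxy in place of ethyl on an aromatic carbon, turning 4-ethylphenyl into 4-methoxyphenyl. Among the measured compounds shown here, the one measured single-place change, fluoro in place of hydrogen, gave a 3.9-fold lower number from compound 1 to compound 2 (0.59 log units; beyond the scatter), but it is a different change and says little about this one. For the measured compounds named here, no measured step covers this swap, so no shift beyond the scatter is expected in this assay. The expected step is a 1.1-fold higher number from compound 1 to compound 4 (0.05 log units; within the scatter). Compound 4 is estimated at 15000 nM, with an expected range from 6000 nM to 35000 nM.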

Compound 4, half-maximal inhibitory concentration: 13500 nM
For compound 4 the middle estimate is 1.1-fold (0.05 log units) above the measured one, within the range that was stated.
By their numbers in this assay, from the lowest: compound 2; then compounds 1 and 4 (each within the scatter of the next); then compound 3.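

Exchanging 4-ethylphenyl for 4-methoxyphenyl gives a 1.0-fold higher number from compound 1 to compound 4 (0.01 log units; within the scatter) in this assay and stays within the scatter. The earlier compounds shown here did not show that this place, para to a large group, tolerates an oxygen where a carbon stood and a hydrogen-bond acceptor that ethyl lacks, with no measurable change in this assay. Nothing at hand explains this flat result. On these data alone, whether an amine, a carboxylic acid or a longer chain here would move the number stays open. So does whether fluoro would lower the number on compound 4 too.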